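The compounds below may be only part of what the source reports. "The series", "measured", "known", "first", "only" and "open" are said of these compounds alone.

Measured so far in an ADME assay on Vero 76 cells (Chlorocebus sabaeus) for cytotoxicity, read by MTT assay, with a stated time of 96 h; a lower number here means that less compound is tolerated, a higher number that more compound is tolerated:
compound 1 `FC(F)(F)c1ccc(NCc2cn(-c3ccccc3)nc2-c2ccc(Br)cc2)cc1` gives 28000 nM;
compound 2 `Cc1ccc(-c2nn(-c3ccccc3)cc2CNc2ccc(C(F)(F)F)cc2)cc1` gives 45000 nM;
compound 3 `FC(F)(F)c1ccc(NCc2cn(-c3ccccc3)nc2-c2ccccc2)cc1` gives 17000 nM.

Going by the values given here, compound 3 holds the lowest of the three numbers, but the gap to compound 1, a 1.6-fold lower number from compound 1 to compound 3 (0.22 log units; within the scatter), is within the scatter; only the step of a 2.6-fold lower number from compound 2 to compound 3 (0.42 log units; beyond the scatter) stands beyond it, and even that one is modest. The three measured compounds differ from one another only on the aryl ring carried by the core, where a 1.6-fold higher number from compound 1 to compound 2 (0.21 log units; within the scatter) also stays within the scatter.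

Compound 4 `Cc1ccc(NCc2cn(-c3ccccc3)nc2-c2ccccc2)cc1` changes a different ring: methyl in place of trifluoromethyl on an aromatic carbon. Among the compounds with values here, none of the measured steps touches this ring or removes a trifluoromethyl, so there is no direct precedent. The closest guide is the step from a methyl-bearing to a hydrogen-bearing ring, a 2.6-fold lower number from compound 2 to compound 3 (0.42 log units; beyond the scatter), which suggests a methyl on an aromatic carbon may go with a somewhat higher number, but that was a different ring and a different group leaving. Taken together, only a small step is expected in this assay, if any, leaning slightly toward a higher number.

For compound 4 a value of about 25000 nM is estimated, in the range 10000 nM to 60000 nM; this corresponds to an expected step of a 1.5-fold higher number from compound 3 to compound 4 (0.17 log units; within the scatter).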

Compound 4, half-maximal cytotoxic concentration: > 100000 nM
Compound 4 gave a limit, no number; the forecaster's own chance of this, stated with the estimate: 10%; middle value at least 4.0-fold (0.60 log units) from the limit.
By their numbers in this assay, from the lowest: compounds 3, 1 and 2 (each within the scatter of the next, the first and the last beyond it). At a limit, above all of these: compound 4.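

In this assay, the ring carrying the trifluoromethyl, a six-membered aromatic ring of carbon only, proves to be a more sensitive place than the aryl ring varied in compounds 1, 2 and 3: an at least 5.8-fold higher number from compound 3 to compound 4 (0.76 log units; beyond the scatter), whereas the largest step on that other ring is a 2.6-fold lower number from compound 2 to compound 3 (0.42 log units; beyond the scatter). Compound 4 reads > 100000 nM, which is a limit of the assay and not a number. The change of trifluoromethyl to methyl at this place therefore moves the series to the top of the measurable range, and its step is only a lower bound on the true size: the limit of > 100000 nM in this assay, at which 1 of the 4 values shown sits.

The compounds shown leave open whether the higher number goes with the loss of trifluoromethyl or the entry of methyl, which a hydrogen, a chloro or a methoxy at this same place would help to separate. Also open, going by these compounds, is whether methyl here keeps the same effect when the aryl ring on the core carries methyl or bromo, as in compound 2 and compound 1.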